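Methoxy on the Phenyl Ring of Two Triterpenoid Cores

This account rests on a few compounds, and the source may have more. Where it says the series, first, only, none or still open, it means among the compounds named here.

Three compounds were tested in a functional assay on A549 cells (Homo sapiens) for cytotoxicity, read by MTT assay, with a stated time of 48 h; a lower number here means a stronger inhibitor, a higher number a weaker inhibitor. Compound 1, `CC(C)=CCC/C(C)=C/CC/C(C)=C/CC[C@@H]1[C@@]2(C)CC/C(=N\OCc3cn(-c4ccccc4)nn3)C(C)(C)[C@@H]2CC[C@@]1(C)O`, gives 6160 nM. Compound 2, `COc1cccc(-n2cc(CO/N=C3\CC[C@]4(C)[C@@H](CC/C=C(\C)CC/C=C(\C)CCC=C(C)C)[C@](C)(O)CC[C@H]4C3(C)C)nn2)c1`, differs from it by methoxy in place of hydrogen on an aromatic carbon, and in this assay compound 2 gives 21700 nM; the step of a 3.5-fold higher number from compound 1 to compound 2 (0.55 log units; beyond the scatter) is a weakening. Compound 3, `CC(C)=CCC/C(C)=C/CC/C(C)=C/CC[C@@H]1[C@@]2(C)C/C(=C\c3ccc(OCc4cn(-c5ccccc5)nn4)cc3)C(=O)C(C)(C)[C@@H]2CC[C@@]1(C)O`, carries a different core; how the two cores differ is not broken down here. In this assay compound 3 gives 100000 nM, the highest number of the three.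

Compound 4, `COc1cccc(-n2cc(COc3ccc(/C=C4\C[C@]5(C)[C@@H](CC/C=C(\C)CC/C=C(\C)CCC=C(C)C)[C@](C)(O)CC[C@H]5C(C)(C)C4=O)cc3)nn2)c1`, has not been measured. It differs from compound 3 by methoxy in place of hydrogen on an aromatic carbon, the same change as between compound 1 and compound 2, in the same kind of place. Because the step of a 3.5-fold higher number from compound 1 to compound 2 (0.55 log units; beyond the scatter) weakened the first pair only modestly, and because compound 3 already gives 100000 nM, little room remains for a further rise. The expected step from compound 3 to compound 4 is no change at the digits printed from compound 3 to compound 4 (within the scatter). Compound 4 is therefore estimated at 100000 nM, with a range from 40000 nM to 250000 nM.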

Compound 4, half-maximal inhibitory concentration: 45700 nM
Estimate against measurement, compound 4: 2.2-fold (0.34 log units) above, and the stated range covers the measured number.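

In this assay, adding the methoxy group gives a 2.2-fold lower number from compound 3 to compound 4 (0.34 log units; beyond the scatter), so the change that weakened the first pair strengthens this one. Set side by side, the two steps run in opposite directions and do not agree within the scatter: the same change on two cores in this assay, a 3.5-fold higher number (0.55 log units; beyond the scatter) from compound 1 to compound 2 and a 2.2-fold lower number (0.34 log units; beyond the scatter) from compound 3 to compound 4, 7.7-fold (0.89 log units) apart, beyond the scatter of two such steps. This shows that the effect of going from phenyl to 3-methoxyphenyl cannot simply be carried from the core of compound 1 to the core of compound 3, but two pairs cannot show why the direction flips or which part of the cores is responsible.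

Going by these compounds, it remains open whether a fluorine atom, a hydroxyl group or an amine in the methoxy group's place would also behave differently on the two cores. On these data alone, it is also open whether the opposite directions would hold in a cell type other than the one used here.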